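Halogen Swap on a Cyclic Sulfonylurea Core

The source may report more compounds than this note shows. Statements on the series, on what has been measured and on what is new or still open speak of the compounds shown alone.

Compound 1 `CCNC1=NS(=O)(=O)c2cc(Cl)c(Cl)cc2N1` and compound 2 `O=S1(=O)NC(NC2CCC2)=Nc2cc(Cl)c(Cl)cc21` share a core, but the difference between the two cores is not broken down here. In a functional assay (aorta) with Rattus norvegicus as the target, with a stated time of 90 min, at 37 degrees C (on this read-out lower numbers stand for an effect already at smaller amounts and higher numbers for an effect only at larger amounts of compound), compound 1 gives 1000 nM, while compound 2 gives 12600 nM, the highest number of the three measured compounds. Compound 3 `CCNC1=NS(=O)(=O)c2cc(Br)c(Cl)cc2N1` carries the change bromo in place of chloro on an aromatic carbon relative to compound 1, and in this assay compound 3 gives 3300 nM; the step of a 3.3-fold higher number from compound 1 to compound 3 (0.52 log units; beyond the scatter) was modest. Compound 4 `O=S1(=O)NC(NC2CCC2)=Nc2cc(Cl)c(Br)cc21` stands to compound 2 as compound 3 stands to compound 1, through the same change (bromo in place of chloro on an aromatic carbon). Resting on that earlier step, compound 4 is expected to show a 3.2-fold higher number from compound 2 to compound 4 (0.50 log units; beyond the scatter). Compound 4 is therefore estimated at 40000 nM in this assay, in a range from 15000 nM to 110000 nM.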

Compound 4, half-maximal effective concentration: 6600 nM
Compound 4: the middle estimate sits 6.1-fold (0.78 log units) above what was measured; measured number outside the range, below it.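

In this assay, replacing chloro with bromo on the core of compound 2 gives a 1.9-fold lower number from compound 2 to compound 4 (0.28 log units; within the scatter), so no shift beyond the usual scatter is seen there. Set beside the step on the core of compound 1, the same change does not carry over in size from one core to the other: the same change on two cores in this assay, a 3.3-fold higher number (0.52 log units; beyond the scatter) from compound 1 to compound 3 and a 1.9-fold lower number (0.28 log units; within the scatter) from compound 2 to compound 4, 6.3-fold (0.80 log units) apart, beyond the scatter of two such steps

This rests on a single pair on each core, so it shows that the earlier step cannot be transferred here but does not show what causes the gap or how the change would behave on any further core. The compounds shown leave open whether the gap persists with a propyl chain or a cyclopentyl group on the exocyclic amine. They also leave open how a fluoro or iodo group on the same aromatic carbon would read on either core.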